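Series notes: two measured compounds, one awaiting measurement

The source may report more compounds than this note shows. Statements on the series, on what has been measured and on what is new or still open speak of the compounds shown alone.

Measured so far:
compound 1 `C/N=C(/NC#N)NCCCCn1nc(N2CCCC2)ccc1=O` — -1%
compound 2 `O=c1ccc(-c2ccccc2)nn1CCCC/N=C(\S)Nc1ccc(S(=O)(=O)O)cc1` — 25.1%

In a functional assay on the whole organism with Rattus norvegicus as the target, at a dose of 100 mg/kg (on this read-out lower numbers stand for less inhibition and higher numbers for more inhibition at the one dose given (going by the name of the read-out)), compound 2 gives 25.1%, the higher of the two numbers shown. The nearest, compound 1, gives -1% in this assay, a gap beyond the scatter. Going by the values given here, compound 1 and compound 2 differ in more than one place, so no single step is known from them.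

Compound 3 `O=c1ccc(-c2ccccc2)nn1CCCC/N=C(\S)Nc1cccc(F)c1` is to be measured in this assay. It differs from compound 2 in one place: 3-fluorophenyl in place of 4-sulfophenyl on an amine nitrogen. Among the compounds with values here, nothing among the measured compounds shows how this change moves the read-out, so the expected step is small. The step of a number 7.1 percentage points lower from compound 2 to compound 3 (within the scatter) is expected to lie within the scatter, leaning slightly downward. Compound 3 is expected to give 18% in this assay, with a range from -5% to 40%.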

Compound 3, a percentage reported as inhibition, in the whole organism at one dose (the size of the read-out at that dose, not a potency): 30.4%
Estimate against measurement, compound 3: 12.4 percentage points below, and the stated range covers the measured number.
By their numbers in this assay, from the lowest: compound 1; then compounds 2 and 3 (each within the scatter of the next).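

In this assay, going by these compounds alone, 3-fluorophenyl in place of 4-sulfophenyl on an amine nitrogen gives a number 5.3 percentage points higher from compound 2 to compound 3 (within the scatter), the first single-place comparison. At this position, the read-out therefore does not separate the two groups, even though the hydrogen-bond donor and acceptors counted on 4-sulfophenyl are absent from 3-fluorophenyl. No measurement shown bears on the reason for this result.

From the compounds shown here alone, it remains open whether a plain phenyl or a phenyl carrying a carboxylic acid at this place would read differently in this assay, and so whether the fluorine or the ring alone accounts for the level seen here. Compound 1 differs from compound 2 and compound 3 in more than one place, so what separates it from them cannot be assigned to any single part.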